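Trading the hydroxyphenylpropyl amine for a butynyl methyl amine

The source may hold more compounds than are shown below. What is called first, only, known or untested is meant among the compounds shown, and "the series" means these compounds.

Measured in an assay on CHO cells for binding affinity to 5-hydroxytryptamine receptor 1D (Homo sapiens); a higher number here means a weaker inhibitor, a lower number a stronger inhibitor:
Compound 1 `COC[C@H](NC1CCN(CCCc2c[nH]c3ccc(-n4cnnc4)cc23)CC1)c1ccccc1`: 3 nM
Compound 2 `OCCC(NC1CCN(CCCc2c[nH]c3ccc(-n4cnnc4)cc23)CC1)c1ccccc1`: 5.5 nM

Compound 2 holds the highest of these two numbers, and its nearest neighbour is compound 1, with the step of a 1.8-fold higher number from compound 1 to compound 2 (0.26 log units; within the scatter). Compound 3 `CC#CCN(C)C1CCN(CCCc2c[nH]c3ccc(-n4cnnc4)cc23)CC1` carries (but-2-yn-1-yl)(methyl)amino in place of (3-hydroxy-1-phenylpropyl)amino on a saturated ring carbon. Within the data shown here, the single measured step, a 1.8-fold higher number from compound 1 to compound 2 (0.26 log units; within the scatter), reworked only the tail on that amine nitrogen and kept the phenyl ring, so it does not directly cover this larger change; no measured pair does. Compound 3 is therefore expected to give 15 nM, likely between 3 nM and 80 nM. That estimate amounts to a step of a 2.7-fold higher number from compound 2 to compound 3 (0.44 log units; beyond the scatter), a weakening expected with low confidence.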

Compound 3, half-maximal inhibitory concentration: 9.8 nM
For compound 3 the middle estimate is 1.5-fold (0.18 log units) above the measured one; measured number inside the range.
By their numbers in this assay, from the lowest: compounds 1, 2 and 3 (each within the scatter of the next, the first and the last beyond it).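

In this assay, the (but-2-yn-1-yl)(methyl)amino group on this saturated ring carbon has no ring and no hydrogen-bond donors, yet it gives a 1.8-fold higher number from compound 2 to compound 3 (0.25 log units; within the scatter). The same group in place of (2-methoxy-1-phenylethyl)amino gives a 3.3-fold higher number from compound 1 to compound 3 (0.51 log units; beyond the scatter), so a modest loss appears only against compound 1. No measured evidence here explains either step. The compounds shown leave open how much of this result belongs to the triple bond and how much to the methyl on the nitrogen. A saturated butyl chain, or a benzyl group on the same amine, would separate these parts.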